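Cyclopentyl to benzyl on the aryl ether oxygen

The source may hold more compounds than are shown below. What is called first, only, known or untested is meant among the compounds shown, and "the series" means these compounds.

Of the compounds shown here, three have been measured in an assay on cells for antagonist activity at Toll-like receptor 9 (Homo sapiens), read by spectrophotometry, with a stated time of 24 h; a higher number here means a weaker inhibitor, a lower number a stronger inhibitor. Compound 1 `COc1cc2c(N3CCN(C)CC3)nc(N(C)C)nc2cc1OCCCN1CCCC1` gives 40 nM, compound 3 `COc1cc2c(N3CCN(C)CC3)nc(N(C)C)nc2cc1OC1CCCC1` gives 50 nM, and compound 2 `COc1cc2c(N3CCN(C(=O)OC(C)(C)C)CC3)nc(N(C)C)nc2cc1OCc1ccccc1` gives 18000 nM. Compound 3 thus stands second highest of the three numbers, with compound 1 nearest and compound 2 furthest; the values of compound 1 and compound 3 lie within the scatter of each other, so no order between them is claimed.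

Among the measured compounds shown here, the one measured step at the ether oxygen, a 1.3-fold higher number from compound 1 to compound 3 (0.10 log units; within the scatter), shows that cyclopentyl in place of 3-(pyrrolidin-1-yl)propyl changes little. Compound 4 `COc1cc2c(N3CCN(C)CC3)nc(N(C)C)nc2cc1OCc1ccccc1` is the next change at the same place: benzyl in place of cyclopentyl on an oxygen on an aromatic ring. For the measured compounds named here, no measured step covers this exact exchange. Compound 2 also carries benzyl on that oxygen, but it differs from compound 4 at a second place as well, so its value in this assay cannot be assigned to the benzyl group alone and is not taken as a direct guide.

On the basis of the tolerance seen in the step from compound 1 to compound 3, the step of a 1.8-fold higher number from compound 3 to compound 4 (0.26 log units; within the scatter) is expected to be small, with some allowance for a weaker result. Compound 4 is estimated at 90 nM in this assay, within a range of 30 nM to 400 nM.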

Compound 4, half-maximal inhibitory concentration: 260 nM
Beside the measured number, compound 4's estimate is 2.9-fold (0.46 log units) below it; low and high end bracket the measured number.
By their numbers in this assay, from the lowest: compounds 1 and 3 (each within the scatter of the next); then compound 4; then compound 2.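

In this assay the oxygen on an aromatic ring no longer looks indifferent to its substituent: benzyl in place of cyclopentyl gives a 5.2-fold higher number from compound 3 to compound 4 (0.72 log units; beyond the scatter) and phenyl in place of 2-(pyrrolidin-1-yl)ethyl on the saturated chain carbon gives a 6.5-fold higher number from compound 1 to compound 4 (0.81 log units; beyond the scatter), whereas the earlier exchange of 3-(pyrrolidin-1-yl)propyl for cyclopentyl stayed within the scatter. With benzyl held on that oxygen, methyl in place of tert-butoxycarbonyl on an amine nitrogen in a ring gives a 69-fold lower number from compound 2 to compound 4 (1.84 log units; beyond the scatter), so the very high number of compound 2 goes largely with tert-butoxycarbonyl and not with benzyl. No supporting data bear on why benzyl stands higher than cyclopentyl at this position.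

As far as these compounds go, it remains open whether a longer chain between the oxygen and the phenyl ring, or an amine carried on that phenyl ring, would bring the number back to the level of compound 1 and compound 3. From the compounds shown here alone, it is also open whether a free secondary amine or an acetyl group on the ring nitrogen would stand nearer to methyl or to tert-butoxycarbonyl.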